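Phenyl added at two nitrogens: working notes on a small series

The source may hold more compounds than are shown below. What is called first, only, known or untested is meant among the compounds shown, and "the series" means these compounds.

Compound 1 `Cn1c(=N)sc2cc(OC(F)(F)F)ccc21` is the reference of the series. In a functional assay on the whole organism with Rattus norvegicus as the target (on this read-out higher numbers stand for an effect only at larger amounts of compound and lower numbers for an effect already at smaller amounts), compound 1 gives 5 mg/kg. Compound 2 `N=c1sc2cc(OC(F)(F)F)ccc2n1Cc1ccccc1` carries the change (phenyl in place of hydrogen on a saturated chain carbon bound to an aromatic nitrogen). In this assay compound 2 gives only a limit, > 10 mg/kg, so the step is an at least 2.0-fold higher number from compound 1 to compound 2 (0.30 log units; that floor lies within the scatter), and what can be said of it rests on (the limit of > 10 mg/kg in this assay, at which 1 of the 3 values shown sits). Compound 3 `CN(C)CCn1c(=N)sc2cc(OC(F)(F)F)ccc21` differs from compound 1 by (dimethylamino)methyl in place of hydrogen on a saturated chain carbon bound to an aromatic nitrogen, which is also all that separates the two cores. In this assay compound 3 gives 2.3 mg/kg, a step of a 2.2-fold lower number from compound 1 to compound 3 (0.34 log units; beyond the scatter). The step of an at least 4.3-fold lower number from compound 2 to compound 3 (0.63 log units; beyond the scatter) connects the two substituted analogues. Of the two numbers shown, compound 3 holds the lower one and compound 1 the nearest.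

Compound 4 `CN(CCn1c(=N)sc2cc(OC(F)(F)F)ccc21)Cc1ccccc1` is not yet measured. It differs from compound 3 by phenyl in place of hydrogen on a saturated chain carbon bound to an amine nitrogen. Among the compounds with values here, this is the same kind of change as the one between compound 1 and compound 2, which gave an at least 2.0-fold higher number from compound 1 to compound 2 (0.30 log units; that floor lies within the scatter), but not the same: the place there is on a saturated chain carbon bound to an aromatic nitrogen, here on a saturated chain carbon bound to an amine nitrogen. The change occurs twice in all among the compounds shown.

For compound 4 in this assay a step of a 2.2-fold higher number from compound 3 to compound 4 (0.34 log units; beyond the scatter) is expected, resting on the earlier step of an at least 2.0-fold higher number from compound 1 to compound 2 (0.30 log units; that floor lies within the scatter) and tempered by the different place. For compound 4 the expected value is 5 mg/kg, estimated to lie between 2 mg/kg and 12 mg/kg.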

Compound 4, dose for half-maximal effect: 7 mg/kg
Beside the measured number, compound 4's estimate is 1.4-fold (0.15 log units) below it; low and high end bracket the measured number.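

In this assay, phenyl in place of hydrogen on a saturated chain carbon bound to an amine nitrogen gives a 3.0-fold higher number from compound 3 to compound 4 (0.48 log units; beyond the scatter), so on the core of compound 3 the change moves the read-out by a step that can be read in full. Set beside the earlier step at the other place, on a saturated chain carbon bound to an aromatic nitrogen, both changes point towards higher numbers, but only the newer step has a known size, and no equal or different size can be claimed: the same change on two cores in this assay, an at least 2.0-fold higher number (0.30 log units; that floor lies within the scatter) from compound 1 to compound 2 and a 3.0-fold higher number (0.48 log units; beyond the scatter) from compound 3 to compound 4; the limit leaves it open whether they differ Two pairs do not make a rule for other cores, and the earlier step remains a floor rather than a measured size because compound 2 carries a limit and not a number: the limit of > 10 mg/kg in this assay, at which 1 of the 4 values shown sits.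

The compounds shown leave open whether a fluorophenyl or a cyclohexyl in place of the phenyl would give a similar step on either core. Also open, going by these compounds, is how the read-out would respond to a longer chain carrying the amine, or to a morpholine or a piperidine in place of the amine of compound 3.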